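An Imidazole Replaces a Cyclohexenyl Group, With No Baseline

This account rests on a few compounds, and the source may have more. Where it says the series, first, only, none or still open, it means among the compounds named here.

Compound 1 `CCN(c1ccc(C#N)c(Cl)c1)c1cc(-c2ccnn2C)ccc1C`: 6230 nM
Compound 2 `CCN(c1ccc(C#N)c(Cl)c1)c1cc(C2=CCCCC2)ccc1C`: "not determined" (no result reported)

In an ADME assay on L02 cells (Homo sapiens) for antiproliferative activity, read by CCK-8 assay, with a stated time of 6 days (a lower number here means a stronger inhibitor, a higher number a weaker inhibitor), compound 2 has no number to stand on: its entry reads "not determined" (no result reported), so it cannot be ranked against compound 1, which gives 6230 nM. The structural change that follows is 1H-imidazol-1-yl in place of cyclohex-1-en-1-yl on an aromatic carbon. It leads to compound 3 `CCN(c1ccc(C#N)c(Cl)c1)c1cc(-n2ccnc2)ccc1C`, with 1H-imidazol-1-yl in place of cyclohex-1-en-1-yl on an aromatic carbon, para to a methyl group and meta to a large group.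

Among the compounds with values here, no measured step shows what such a swap does in this assay, and the starting point of this one is itself unmeasured. Within the data shown here, the only number available is that of compound 1 at 6230 nM, so the expectation is a result near that level, with no shift in either direction beyond the scatter. The estimate for compound 3 is an expected 6000 nM, within a range of 2000 nM to 18000 nM.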

Compound 3, half-maximal inhibitory concentration: 15000 nM
The estimate for compound 3 lay 2.5-fold (0.40 log units) below the measured number; measured number inside the range.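

In this assay, this position, para to a methyl group, now has one readable step: with 1H-imidazol-1-yl in place of 1-methyl-1H-pyrazol-5-yl, the number moves a 2.4-fold higher number from compound 1 to compound 3 (0.38 log units; beyond the scatter), a modest shift toward weaker inhibition, so these two groups do not read alike here. From the compounds shown here alone, the change from cyclohex-1-en-1-yl to 1H-imidazol-1-yl cannot be read, and the effect of that swap in this assay remains unknown, with compound 2 offering no number to compare. Nothing available explains the shift seen between the two heterocyclic groups.

Going by these compounds, whether an amine, a carboxylic acid or a longer chain on this aromatic carbon would move the number further, and in which direction, stays open. The compounds shown also leave open whether a six-membered ring of carbon only is tolerated at this position.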